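Bromo to methylsulfanyl on a purine nucleoside core

This account rests on a few compounds, and the source may have more. Where it says the series, first, only, none or still open, it means among the compounds named here.

Measured compounds:
compound 1, `CNc1nc(SC)nc2c1ncn2[C@@H]1C[C@@H](O)[C@H](CO)O1`: > 300 uM
compound 2, `Nc1nc(Br)nc2c1ncn2[C@@H]1C[C@@H](O)[C@H](CO)O1`: 83 uM

In a functional assay on K562 cells (Homo sapiens) (on this read-out lower numbers stand for stronger inhibition and higher numbers for weaker inhibition), compound 1 reaches only the limit of the assay at > 300 uM and gives no number. For the measured compounds named here, compound 2 is the only measured compound with a number in this assay, where compound 2 gives 83 uM. Compound 3, `CSc1nc(N)c2ncn([C@@H]3C[C@@H](O)[C@H](CO)O3)c2n1`, has not yet been measured. It differs from compound 2 by methylsulfanyl in place of bromo on an aromatic carbon. Going by the values given here, no step between two measured compounds is known, so the size of this change has no direct precedent. Given that one of the two values shown sits at the limit of > 300 uM in this assay, at which 1 of the 2 values shown sits, the account expects a step from compound 2 to compound 3 toward weaker inhibition, estimated as a 2.4-fold higher number from compound 2 to compound 3 (0.38 log units; beyond the scatter), beyond the usual scatter. Compound 3 is therefore estimated at 200 uM, within a range from 60 uM to 600 uM.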

Compound 3, concentration for 50% inhibition: > 300 uM
Compound 3: only a limit was reported; the forecaster's own chance of this, stated with the estimate: 40%; middle value at least 1.5-fold (0.17 log units) from the limit.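

In this assay, for the compounds shown here, methylsulfanyl in place of bromo on an aromatic carbon between two ring nitrogen atoms gives an at least 3.6-fold higher number from compound 2 to compound 3 (0.55 log units; beyond the scatter), the first measured step at this position, and it lies beyond the scatter. The value of compound 3, > 300 uM, is a limit of the assay and not a number, so of the compounds shown only bromo at this position gives a number. The step of hydrogen in place of methyl on the nitrogen cannot be read, and limits dominate the values shown: the limit of > 300 uM in this assay, at which 2 of the 3 values shown sit.

The compounds shown leave open how large the step from bromo to methylsulfanyl really is. They also leave open whether a chlorine, a methoxy group or an amine at this position would give a number in this assay.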